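A few compounds are considered here, and "the series" means these few. Any claim that something is new, unique, unknown or untested is made for them only; others in the source may bear on it.

Compound 1 `Cc1cc(/C=C2\S/C(=N\c3ccccc3)N(C3CCCCC3)C2=O)c(C)n1-c1ccc(C(F)(F)F)cc1`: > 170000 nM
Compound 2 `O=C1/C(=C/c2ccn(-c3ccccc3C(F)(F)F)c2)S/C(=N\c2ccccc2)N1C1CCCCC1`: > 180000 nM

Both readings come from an ADME assay on L6 cells (Rattus norvegicus) for cytotoxicity, read by microscopy and resazurin assay, with a stated time of 72 h; on this read-out higher numbers stand for an effect only at larger amounts of compound and lower numbers for an effect already at smaller amounts. In this assay compound 1 stands at > 170000 nM, which is a limit and not a number. Compound 2 gives > 180000 nM, which is also a limit. Neither compound therefore has a measured number, and no step can be read from this pair.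

Compound 3 `Cc1cc(/C=C2\S/C(=N\c3ccccc3)N(C3CCCCC3)C2=O)c(C)n1C` keeps the core of compound 1 and differs in one group: methyl in place of 4-(trifluoromethyl)phenyl on an aromatic nitrogen. That nitrogen lies in a five-membered aromatic ring, next to two ring atoms that each bear a methyl group.

Among the compounds with values here, the only anchor for compound 3 is the limit of compound 1 at > 170000 nM, so any expectation is loose. A large move in this assay is not expected, and the reading may again be only a limit. The estimated step runs an at least 1.7-fold lower number from compound 1 to compound 3 (0.23 log units; that floor lies within the scatter), a modest one toward lower numbers. For compound 3 the expected value is 100000 nM, with an estimated range from 30000 nM to 240000 nM.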

Compound 3, half-maximal effective concentration: > 230000 nM
Compound 3 ended at the assay's limit (the forecaster's own chance of this, stated with the estimate: 55%); at least 2.3-fold (0.36 log units) between middle value and limit.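

In this assay compound 1 gives > 170000 nM, which is a limit. Compound 3 gives > 230000 nM, which is also a limit. The step between these two compounds therefore cannot be read. The compounds shown leave open whether methyl in place of 4-(trifluoromethyl)phenyl on an aromatic nitrogen changes this reading at all.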